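The compounds below may be only part of what the source reports. "The series", "measured", "known", "first", "only" and "open" are said of these compounds alone.

Compound 1 `CC1=CC[C@H]2[C@H](CC[C@]2(C)O)C(C)(C)[C@@H]1CC[C@H]1[C@]2(C)CC[C@H](OC(=O)CCC(=O)O)C(C)(C)O[C@H]2CC[C@@]1(C)O` stands only at a limit: in a functional assay on MCF7 cells (Homo sapiens) for antiproliferative activity, read by MTT assay, with a stated time of 72 h (on this read-out higher numbers stand for weaker inhibition and lower numbers for stronger inhibition), compound 1 gives > 50000 nM, which is a limit of the assay and not a number. Compound 2 `CC1=CC[C@H]2[C@H](CC[C@]2(C)O)C(C)(C)[C@@H]1CC[C@H]1[C@]2(C)CC[C@H](OC(=O)c3ccc(C)cc3)C(C)(C)O[C@H]2CC[C@@]1(C)O` likewise gives > 50000 nM in this assay, again a limit. Compound 3 `CC1=CC[C@H]2[C@H](CC[C@]2(C)O)C(C)(C)[C@@H]1CC[C@H]1[C@]2(C)CC[C@H](OCc3ccccc3)C(C)(C)O[C@H]2CC[C@@]1(C)O` gives > 50000 nM in this assay, also a limit. Compound 4 `CC1=CC[C@H]2[C@H](CC[C@]2(C)O)C(C)(C)[C@@H]1CC[C@H]1[C@]2(C)CC[C@H](OC(=O)c3ccco3)C(C)(C)O[C@H]2CC[C@@]1(C)O` differs from compound 1 by furan-2-yl in place of 2-carboxyethyl on a carbonyl carbon. The step from compound 1 to compound 2 a step that the two limits leave unreadable from compound 1 to compound 2 exchanges the same 2-carboxyethyl group for an aromatic ring and is the closest comparison, but its size cannot be read, and the same holds for a step that the two limits leave unreadable from compound 1 to compound 3 and a step that the two limits leave unreadable from compound 2 to compound 3, since (the limit of > 50000 nM in this assay, at which 3 of the 3 values shown sit). He therefore expects the step that the limit leaves unreadable from compound 1 to compound 4 to be unreadable as well, with compound 4 estimated at 70000 nM in this assay, within 20000 nM to 300000 nM.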

Compound 4, half-maximal inhibitory concentration: 25700 nM
Estimate against measurement, compound 4: 2.7-fold (0.44 log units) above, and the stated range covers the measured number.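

In this assay, compound 4 alone among the four compounds gives a number rather than a limit, which gives the change to furan-2-yl on this carbonyl carbon a lower bound on its size: an at least 1.9-fold lower number from compound 1 to compound 4 (0.28 log units; that floor lies within the scatter), an at least 1.9-fold lower number from compound 2 to compound 4 (0.28 log units; that floor lies within the scatter) and an at least 1.9-fold lower number from compound 3 to compound 4 (0.28 log units; that floor lies within the scatter). The steps among compound 1, compound 2 and compound 3 still cannot be read: the limit of > 50000 nM in this assay, at which 3 of the 4 values shown sit.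

On these data alone, what remains open is how a thiophen-2-yl or pyridin-3-yl group on the same carbonyl carbon would read in this assay.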